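The compounds below may be only part of what the source reports. "The series", "measured", "known", "first", "only" and "open" are said of these compounds alone.

Three compounds of a shared core are known in a toxicity assay on GES1 cells (Homo sapiens) for inhibition, read by MTT assay, with a stated time of 72 h; on this read-out higher numbers stand for weaker inhibition and lower numbers for stronger inhibition. Compound 1 `Cc1cc(N2CC[C@@H](C)[C@@H](N(C)c3ncnc4[nH]ccc34)C2)n2nc(SCc3nc4ccccc4[nH]3)nc2n1` gives 40200 nM in this assay. Compound 3 `Cc1cc(N2CC[C@@H](C)[C@@H](N(C)c3ncnc4[nH]ccc34)C2)n2nc(SCCc3ccccc3)nc2n1` gives 66200 nM. For compound 2 `Cc1cc(N2CC[C@@H](C)[C@@H](N(C)c3ncnc4[nH]ccc34)C2)n2nc(SCc3csc4ccc(Cl)cc34)nc2n1` this assay reports only a limit, > 100000 nM, so compound 2 stands with a bound and no number among the three. The step of an at least 2.4-fold higher number from compound 1 to compound 2 (0.39 log units; beyond the scatter) is read against that limit (the limit of > 100000 nM in this assay, at which 1 of the 3 values shown sits), and the step of an at least 1.5-fold lower number from compound 2 to compound 3 (0.17 log units; that floor lies within the scatter) rests on the same limit. Compound 4 `Cc1cc(N2CC[C@@H](C)[C@@H](N(C)c3ncnc4[nH]ccc34)C2)n2nc(SCc3ccc(C(F)(F)F)cc3)nc2n1` differs from compound 2 in one place: 4-(trifluoromethyl)phenyl in place of 5-chloro-1-benzothiophen-3-yl on a saturated chain carbon bound to a sulfur. The two steps that bear on it, an at least 2.4-fold higher number from compound 1 to compound 2 (0.39 log units; beyond the scatter) and an at least 1.5-fold lower number from compound 2 to compound 3 (0.17 log units; that floor lies within the scatter), are both bounded by the limit of compound 2, so the size of the step to compound 4 cannot be fixed from them. The nearest measured neighbour in shape is compound 3, which gives 66200 nM. Compound 4 is therefore expected to give 80000 nM, between 35000 nM and 200000 nM, an expected step of an at least 1.2-fold lower number from compound 2 to compound 4 (0.09 log units; that floor lies within the scatter), with a fair chance that this assay again reports only a limit.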

Compound 4, half-maximal inhibitory concentration: 17300 nM
Beside the measured number, compound 4's estimate is 4.6-fold (0.67 log units) above it; the measured number lies below the stated range.
By their numbers in this assay, from the lowest: compound 4; then compounds 1 and 3 (each within the scatter of the next). At a limit, above all of these: compound 2.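

In this assay, the position on the saturated chain carbon bound to a sulfur now shows a clear separation, which compound 1 and compound 3 did not show on their own: a 3.8-fold lower number from compound 3 to compound 4 (0.58 log units; beyond the scatter) and a 2.3-fold lower number from compound 1 to compound 4 (0.37 log units; beyond the scatter). Exchanging 5-chloro-1-benzothiophen-3-yl for 4-(trifluoromethyl)phenyl, at an equal count of heavy atoms, gives an at least 5.7-fold lower number from compound 2 to compound 4 (0.76 log units; beyond the scatter), so compound 4 inhibits most strongly of the four. That last step is only a floor, as compound 2 has no exact number: the limit of > 100000 nM in this assay, at which 1 of the 4 values shown sits.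

From the compounds shown here alone, whether a plain benzyl, a 4-chlorobenzyl or a 4-methoxybenzyl on the sulfur would behave like compound 4 remains open. Going by these compounds, how an amine or a carboxylic acid on that phenyl ring would move the number in this assay also remains open.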